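A few compounds are considered here, and "the series" means these few. Any claim that something is new, unique, unknown or untested is made for them only; others in the source may bear on it.

In a functional assay on HepG2 cells (Homo sapiens) for cytotoxicity, read by MTT assay, with a stated time of 72 h (a lower number here means a stronger inhibitor, a higher number a weaker inhibitor), compound 1 `CNC(=O)c1cc(Oc2ccc(C3CC(c4ccc([N+](=O)[O-])cc4)=NN3)cc2)ccn1` gives 28900 nM, level with compound 2 `CNC(=O)c1cc(Oc2ccc(C3CC(c4ccc(Br)cc4)=NN3)cc2)ccn1` at 16900 nM. Compound 3 `CNC(=O)c1cc(Oc2ccc(C3CC(c4ccc([N+](=O)[O-])cc4)=NN3C(N)=S)cc2)ccn1` keeps the core of compound 1 and carries one change, on an amine nitrogen in a ring: a group of 3 heavy atoms (1 carbon, 1 nitrogen, 1 sulfur; no ring) in place of a hydrogen atom, on an amine nitrogen in a ring. Among the compounds with values here, the only measured step, a 1.7-fold lower number from compound 1 to compound 2 (0.23 log units; within the scatter), lies elsewhere in the molecule and stays within the scatter, so it says little about this nitrogen. Within the data shown here, no measured compound carries any group there, so the expectation is loose. The expected step is a 1.9-fold lower number from compound 1 to compound 3 (0.28 log units; within the scatter), no larger than the scatter. For compound 3 the estimated value is 15000 nM, with an expected range from 4000 nM to 45000 nM.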

Compound 3, half-maximal inhibitory concentration: > 50000 nM
Compound 3: a limit, no number; the forecaster's own chance of this, stated with the estimate: 10%; middle value at least 3.3-fold (0.52 log units) away from the limit.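

In this assay, compound 3 gives only a limit of the assay, not a number: the limit of > 50000 nM in this assay, at which 1 of the 3 values shown sits. Within the data shown here, this is the first view of a group on this amine nitrogen in a ring, and replacing the hydrogen atom gives an at least 1.7-fold higher number from compound 1 to compound 3 (0.23 log units; that floor lies within the scatter). On these data alone, the change therefore brings no gain in strength, although the true size of the step remains unknown.

The compounds shown leave open whether a methyl or acetyl group on this nitrogen would read differently. They also leave open how the same group behaves alongside the bromo group of compound 2.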